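This account rests on a few compounds, and the source may have more. Where it says the series, first, only, none or still open, it means among the compounds named here.

Measured compounds:
Compound 1, `COc1ccc(C2=NN(C3=NC(=O)/C(=C4\C(=O)Nc5ccc(Br)cc54)S3)C(c3ccc(OC)cc3)C2)cc1`: 280 nM
Compound 2, `COc1ccc(C2=NN(C3=NC(=O)/C(=C4\C(=O)Nc5ccccc54)S3)C(c3ccc(Cl)cc3)C2)cc1`: 86600 nM

Both were run in a functional assay on cells (Leukemia cell, Homo sapiens) for cytotoxicity, read by sulforhodamine B assay, with a stated time of 48 h; on this read-out lower numbers stand for stronger inhibition of growth and higher numbers for weaker inhibition of growth. Compound 1 gives 280 nM in this assay, while compound 2 gives 86600 nM, the higher of the two numbers and far beyond the scatter from compound 1. Within the data shown here, compound 1 and compound 2 differ in two places, so no single step between them can be read from these values.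

Compound 3, `COc1ccc(C2=NN(C3=NC(=O)/C(=C4\C(=O)Nc5ccc(Br)cc54)S3)C(c3ccc(Cl)cc3)C2)cc1`, has not been measured. It differs from compound 2 by bromo in place of hydrogen on an aromatic carbon, so that compound 3 carries the bromo of compound 1 together with the chloro-bearing aryl of compound 2.

Expectation: the bromo is the one part of compound 1 that compound 2 lacks on the fused ring, and compound 1 sits at 280 nM while compound 2 sits at the much higher 86600 nM, so a step toward lower numbers, well beyond the scatter, is expected for a 35-fold lower number from compound 2 to compound 3 (1.54 log units; beyond the scatter), though the chloro-bearing aryl is kept and its share of the gap is unknown. For compound 3 an estimated value of 2500 nM is given, within a range from 300 nM to 25000 nM.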

Compound 3, concentration for 50% growth inhibition: 190 nM
The estimate for compound 3 lay 13-fold (1.12 log units) above the measured number; the whole stated range lies above it.
By their numbers in this assay, from the lowest: compounds 3 and 1 (each within the scatter of the next); then compound 2.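

Read in this assay, the single change of bromo in place of hydrogen on an aromatic carbon of the fused system gives a 460-fold lower number from compound 2 to compound 3 (2.66 log units; beyond the scatter) and is the first one-place step in the series, showing that this carbon alone can carry a very large difference when the chloro-bearing aryl is held constant. With the bromo kept, chloro in place of methoxy on the aromatic carbon of the other aryl gives a 1.5-fold lower number from compound 1 to compound 3 (0.17 log units; within the scatter) and so stays within the scatter, which means that in the presence of the bromo the two aryl substituents are not told apart on this read-out. No measurement at hand explains the size of the bromo step or why the aryl exchange is silent.

The compounds shown leave open whether removing the bromo would cost as much with the methoxy-bearing aryl, and whether the gain belongs to bromo itself or would also come with fluoro, methyl or an amine on that aromatic carbon. From the compounds shown here alone, it also remains open whether a carboxylic acid or a longer chain on the aryl would stay as silent as the exchange of chloro and methoxy does.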